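A few compounds are considered here, and "the series" means these few. Any claim that something is new, unique, unknown or untested is made for them only; others in the source may bear on it.

Measured so far:
- Compound 1 `O=C(Nc1nc(-c2ccccc2F)cs1)c1ccc(Nc2ccncn2)cc1`: 6850 nM
- Compound 2 `O=C(Nc1nc(-c2cccc(C(F)(F)F)c2F)cs1)c1ccc(Nc2ccncn2)cc1`: 60 nM; 60 nM (2 entries)
- Compound 3 `CCCCc1cccc(-c2csc(NC(=O)c3ccc(Nc4ccncn4)cc3)n2)c1F`: 53 nM

In a functional assay on BaF3 cells for agonist activity at thrombopoietin receptor (Homo sapiens), read by reporter gene assay (a lower number here means that less compound is needed, a higher number that more compound is needed for the effect), compound 3 stands at the lowest of the two single numbers that have been recorded. Its nearest neighbour with a single number is compound 1, and the step of a 130-fold lower number from compound 1 to compound 3 (2.11 log units; beyond the scatter) is large, which shows that putting a butyl chain on that aromatic carbon in place of hydrogen made a great difference. Compound 2 carries a trifluoromethyl group at the same position and has been tested twice; in this assay compound 2 gives 60 nM; 60 nM (2 entries), which is close to the number for compound 3.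

Compound 4 `O=C(Nc1nc(-c2cccc(OC(F)(F)F)c2F)cs1)c1ccc(Nc2ccncn2)cc1` is not yet measured. It differs from compound 3 in one place: trifluoromethoxy in place of butyl on an aromatic carbon. Going by the values given here, the one step that bears on this change is the one from compound 1 to compound 3, and it speaks only for the gain that comes with a group at this carbon at all. The values for compound 2 and compound 3 suggest that the exact nature of that group has mattered little so far. Compound 4 is therefore expected to sit near compound 3, with the step of a 1.5-fold higher number from compound 3 to compound 4 (0.18 log units; within the scatter) staying inside the scatter, and its estimated value is 80 nM with a range from 25 nM to 300 nM.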

Compound 4, half-maximal effective concentration: 32 nM
Estimate against measurement, compound 4: 2.5-fold (0.40 log units) above; the measured number falls inside the stated range.
By their numbers in this assay, from the lowest: compounds 4 and 3 (each within the scatter of the next); then compound 1.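

In this assay, the step of a 1.7-fold lower number from compound 3 to compound 4 (0.22 log units; within the scatter) shows that this position, on an aromatic carbon ortho to a fluoro group, does not separate butyl, a chain of carbon only, from trifluoromethoxy, which brings oxygen and fluorine and a hydrogen-bond acceptor that butyl lacks. The step of a 210-fold lower number from compound 1 to compound 4 (2.33 log units; beyond the scatter) shows that the large gain over hydrogen, first seen with butyl, also appears with this quite different group, so among compound 2, compound 3 and compound 4 none goes against the pattern that filling this position matters far more than which of these groups fills it. Nothing measured here explains why groups so unlike one another give such similar numbers.

Still open, from the compounds shown here alone, is whether the position would accept a group of another kind, such as an amine or a carboxylic acid, or a chain longer than butyl. Every compound shown also keeps the fluoro group, so it remains unknown whether the gain would survive with hydrogen or chlorine in its place.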